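Chloro to Bromo at Two Ring Positions, Cytotoxicity Compared

The source may report more compounds than this note shows. Statements on the series, on what has been measured and on what is new or still open speak of the compounds shown alone.

Three compounds have been measured in an ADME assay on NIH3T3 cells (Mus musculus) for cytotoxicity, read by XTT assay, with a stated time of 24 h; on this read-out lower numbers stand for stronger inhibition and higher numbers for weaker inhibition:

compound 1 `Cn1nnnc1SCC(=O)N/N=C/c1ccc(Cl)cc1`: 2100000 nM
compound 2 `Cn1nnnc1SCC(=O)N/N=C/c1ccc(Br)cc1`: 10000000 nM
compound 3 `Cn1nnnc1SCC(=O)N/N=C/c1ccccc1Cl`: > 10000000 nM

Compound 1 and compound 2 share a core and differ by bromo in place of chloro on an aromatic carbon. In this assay this gives a 4.8-fold higher number from compound 1 to compound 2 (0.68 log units; beyond the scatter).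

For compound 3 the number is not a number but a limit of the assay, (the limit of > 10000000 nM in this assay, at which 1 of the 3 values shown sits). Compound 1 and compound 3 are built from the same atoms joined differently, and the difference between the two cores is not broken down here.

Compound 4 `Cn1nnnc1SCC(=O)N/N=C/c1ccccc1Br` has not yet been measured in this assay. It differs from compound 3 by bromo in place of chloro on an aromatic carbon. Among the measured compounds shown here, this is the same kind of change as the one from compound 1 to compound 2, but not the same: in the measured pair the halogen sits para to a large group, whereas in compound 3 and compound 4 it sits ortho to a large group.

Set beside a 4.8-fold higher number from compound 1 to compound 2 (0.68 log units; beyond the scatter), the step from compound 3 to compound 4 in this assay is expected to be a number no higher from compound 3 to compound 4 (the limit leaves the size open), though this rests on a single measured pair and on the fact that compound 3 itself gave only a limit. Compound 4 is therefore estimated at 10000000 nM, with a range from 4000000 nM to 25000000 nM, and it is expected that the assay will most likely again report only a limit.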

Compound 4, half-maximal inhibitory concentration: 20000 nM
Compound 4: the middle estimate sits 500-fold (2.70 log units) above what was measured; measured number outside the range, below it.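

In this assay, bromo in place of chloro on an aromatic carbon, ortho to a large group, gives an at least 500-fold lower number from compound 3 to compound 4 (2.69 log units; beyond the scatter). Set beside the earlier step, the same change does not carry from one core to the other, in size or in direction: the same change on two cores in this assay, a 4.8-fold higher number (0.68 log units; beyond the scatter) from compound 1 to compound 2 and an at least 500-fold lower number (2.69 log units; beyond the scatter) from compound 3 to compound 4, at least 2300-fold (3.37 log units) apart, beyond the scatter of two such steps. For compound 3 the value > 10000000 nM is a limit of the assay and not a number, so the new step has only a lower bound, and two pairs of compounds neither give a rule for this change nor show why the two steps part: the limit of > 10000000 nM in this assay, at which 1 of the 4 values shown sits.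

The compounds shown leave open whether the low number of compound 4 belongs to bromo alone at this place or would also appear with iodo, fluoro or methyl on the same ring carbon. They also leave open how the two cores would respond to a change of another kind, such as an amine or a carboxylic acid on the ring, and so whether the split seen here is particular to the swap of chloro for bromo.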